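The source may hold more compounds than are shown below. What is called first, only, known or untested is meant among the compounds shown, and "the series" means these compounds.

Compound 1 `CC(C)(C)OC(=O)N1CCC(O[C@H]2CC[C@H](Oc3cnc(S(C)(=O)=O)cn3)CC2)CC1`: 110%
Compound 2 `CS(=O)(=O)c1cnc(O[C@H]2CC[C@H](OC3CCN(C(=O)C4(C(F)(F)F)CCCC4)CC3)CC2)cn1`: 95%
Compound 3 `CS(=O)(=O)c1cnc(O[C@H]2CC[C@H](OC3CCN(CC4(C(F)(F)F)CCC4)CC3)CC2)cn1`: 96%

In a functional assay on isolated protein for agonist activity at Glucose-dependent insulinotropic receptor (Homo sapiens), read by HTRF and cAMP accumulation (a higher number here means a larger maximal response, a lower number a smaller maximal response), compound 3 stands second highest of the three numbers; its nearest neighbour is compound 2, and its furthest is compound 1. Compound 4 `CS(=O)(=O)c1cnc(O[C@H]2CC[C@H](OC3CCN(CC4(C(F)(F)F)CCCC4)CC3)CC2)cn1` differs from compound 3 in one place: a group of 9 heavy atoms (6 carbon, 3 fluorine; one five-membered non-aromatic ring of carbon only) in place of a group of 8 heavy atoms (5 carbon, 3 fluorine; one four-membered non-aromatic ring of carbon only), on a saturated chain carbon bound to an amine nitrogen in a ring. The step that bears most on this change is a number 1 percentage points higher from compound 2 to compound 3 (within the scatter), where a five-membered ring also stood against a four-membered one, while both a number 15 percentage points lower from compound 1 to compound 2 (beyond the scatter) and a number 14 percentage points lower from compound 1 to compound 3 (beyond the scatter) show the two ring-bearing compounds landing close together. The expected step of no change at the digits printed from compound 3 to compound 4 (within the scatter) is therefore none beyond the scatter. Compound 4 is estimated at 96%, with a range from 86% to 106%.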

Compound 4, largest response reached (Emax), in percent of the reference or control that the assay uses: 37%
For compound 4 the middle estimate is 59 percentage points above the measured one; the whole stated range lies above it.
By their numbers in this assay, from the lowest: compound 4; then compounds 2 and 3 (each within the scatter of the next); then compound 1.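

In this assay, moving from 1-(trifluoromethyl)cyclobutyl to its five-membered ring counterpart on this saturated chain carbon brings a number 59 percentage points lower from compound 3 to compound 4 (beyond the scatter), so ring size at this place can matter greatly. The five-membered ring alone does not mark a low response, since replacing the carbonyl link of the earlier compound with the saturated chain carbon gives a number 58 percentage points lower from compound 2 to compound 4 (beyond the scatter). Against the tert-butoxycarbonyl compound, the change is a number 73 percentage points lower from compound 1 to compound 4 (beyond the scatter).

Nothing measured here explains this loss. Going by these compounds, whether a 1-(trifluoromethyl)cyclopropyl or a cyclohexyl group would keep or lose the response remains open.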